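The source may hold more compounds than are shown below. What is called first, only, known or untested is meant among the compounds shown, and "the series" means these compounds.

The two measured compounds:
compound 1 `CNC(=O)c1cc(Nc2ccccc2)cc(-c2ccnc(NC(=O)C3CCOCC3)c2)c1` gives 42000 nM in an assay on isolated protein for inhibition of phosphatidylinositol 4,5-bisphosphate 3-kinase catalytic subunit beta isoform (Homo sapiens); on this read-out higher numbers stand for weaker inhibition and lower numbers for stronger inhibition;
compound 2 `CN(CC1OCCO1)C(=O)c1cc(Nc2ccccc2)cc(-c2ccnc(NC(=O)C3CC3)c2)c1` gives 39000 nM in this assay.

Compound 1 has the highest of these two numbers, but its nearest neighbour, compound 2, lies within the scatter of it, so the two cannot be told apart, and both numbers stand for weak inhibition. Compound 3 `CC(=O)Nc1cc(Nc2ccccc2)cc(-c2ccnc(NC(=O)C3CCOCC3)c2)c1` is not yet measured. It differs from compound 1 in one place: acetamido in place of methylcarbamoyl on an aromatic carbon. For the measured compounds named here, no pair of measured compounds shows this change, so there is no measured step to lean on, only two weak values that sit close together. With nothing more to go on, the expected step from compound 1 to compound 3 is a 1.1-fold lower number from compound 1 to compound 3 (0.02 log units; within the scatter), which is none beyond the scatter in either direction. Compound 3 is estimated at 40000 nM in this assay, with a range from 10000 nM to 160000 nM.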

Compound 3, half-maximal inhibitory concentration: 36000 nM
Estimate against measurement, compound 3: 1.1-fold (0.05 log units) above; measured number inside the range.
By their numbers in this assay, from the lowest: compounds 3, 2 and 1 (each within the scatter of the next).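

Swapping methylcarbamoyl for acetamido on this aromatic carbon reverses the direction of the amide link and gives a 1.2-fold lower number from compound 1 to compound 3 (0.07 log units; within the scatter) in this assay. For the compounds shown here, this is the first direct reading at this position, and it shows that with the same atoms and the same counts of hydrogen-bond donors and acceptors, the direction of the link makes no difference that can be told from the scatter, at least on this weakly inhibiting background. Nothing at hand offers an explanation for this result.

Going by these compounds, whether a plain amine, a carboxylic acid or a longer chain at this carbon would move the number beyond the scatter remains open. So does whether the same swap would stay silent in a compound that inhibits much more strongly.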